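The compounds below may be only part of what the source reports. "The series", "measured", "known", "first", "only" and "open" are said of these compounds alone.

Compound 3, with the structure `COc1cc(Cl)cc(-c2nn(-c3cccc(NC(=O)Nc4ccc(Cl)c(C(F)(F)F)c4)c3)cc2-c2ccncc2)c1`, shows the lowest of the three numbers in a functional assay on UACC-62 cells (Homo sapiens) for inhibition, read by sulforhodamine B assay, with a stated time of 48 h, tested at 0.1 uM (a higher number here means a weaker effect of the compound at the concentration tested, a lower number a stronger effect), giving 93%; compound 2, with the structure `O=C(Nc1cccc(-n2cc(-c3ccncc3)c(-c3cc(O)cc(Cl)c3)n2)c1)Nc1ccc(Cl)c(Cl)c1`, gives 99%, and compound 1, with the structure `O=C(Nc1cccc(-n2cc(-c3ccncc3)c(-c3cc(O)cc(Cl)c3)n2)c1)Nc1ccc(Cl)c(C(F)(F)F)c1`, gives 102%, so that none of the three is separated from another by more than the usual scatter. Compound 4, with the structure `COc1cc(Cl)cc(-c2nn(-c3cccc(NC(=O)Nc4ccc(Cl)c(Cl)c4)c3)cc2-c2ccncc2)c1`, differs from compound 3 in one place: chloro in place of trifluoromethyl on an aromatic carbon. The same change has been measured once already, between two compounds that carry hydrogen rather than methyl on the oxygen of the aromatic ring, and there it gave a number 3 percentage points lower from compound 1 to compound 2 (within the scatter). The other measured step, a number 9 percentage points lower from compound 1 to compound 3 (within the scatter), is likewise within the scatter. Because the step of a number 3 percentage points lower from compound 1 to compound 2 (within the scatter) stayed within the scatter, no movement beyond it is expected here either, and the step from compound 3 to compound 4 is estimated at a number 2 percentage points lower from compound 3 to compound 4 (within the scatter). Compound 4 is therefore expected to give about 91% in this assay , with a likely range from 80% to 102%.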

Compound 4, a percentage reported as activity, at one concentration (the size of the read-out at that concentration, not a potency): 97%
The estimate for compound 4 lay 6 percentage points below the measured number; the range from low to high includes it.
By their numbers in this assay, from the lowest: compounds 3, 4, 2 and 1 (each within the scatter of the next).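

In this assay the change from trifluoromethyl to chloro, on an aromatic carbon ortho to a chloro group, gives a number 4 percentage points higher from compound 3 to compound 4 (within the scatter) on the core that carries methyl on the oxygen, so the change has now been read on two cores and stays within the scatter on both: the same change on two cores in this assay, a number 3 percentage points lower (within the scatter) from compound 1 to compound 2 and a number 4 percentage points higher (within the scatter) from compound 3 to compound 4, 7 percentage points apart, within the scatter of two such steps. The methyl on the oxygen, read with the 3,4-dichlorophenyl group in place, gives a number 2 percentage points lower from compound 2 to compound 4 (within the scatter) and agrees with its reading on the other core: the same change on two cores in this assay, a number 9 percentage points lower (within the scatter) from compound 1 to compound 3 and a number 2 percentage points lower (within the scatter) from compound 2 to compound 4, 7 percentage points apart, within the scatter of two such steps. Neither change therefore shows a dependence on the other beyond the scatter in this assay.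

On these data alone, what remains open is whether a group of another kind at this position, such as an amine, a carboxylic acid or a nitrile, would move the number. As far as these compounds go, it is also open whether these compounds would separate at any other concentration.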